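This account rests on a few compounds, and the source may have more. Where it says the series, first, only, none or still open, it means among the compounds named here.

Series notes on the core shared by compound 1 `Cn1c(N)nc2c1c(=O)n(CC1CC1)c(=O)n2CC1CC1`, compound 2 `CC(C)Cn1c(N)nc2c1c(=O)n(CC1CC1)c(=O)n2CC1CC1` and compound 3 `COc1ccc(Cn2c(N)nc3c2c(=O)n(CC2CC2)c(=O)n3CC2CC2)cc1`, all measured in an assay on isolated protein with dual specificity calcium/calmodulin-dependent 3',5'-cyclic nucleotide phosphodiesterase 1B (Bos taurus) as the target, tested at 100 uM; on this read-out lower numbers stand for less inhibition and higher numbers for more inhibition at the one concentration tested (going by the name of the read-out). Compound 1 gives 30%, compound 2 gives 12% and compound 3 gives 60%. Compound 3 stands highest of the three numbers: the nearest is compound 1, with the step of a number 30 percentage points higher from compound 1 to compound 3 (beyond the scatter), and the furthest is compound 2, with the step of a number 48 percentage points higher from compound 2 to compound 3 (beyond the scatter). The remaining step, a number 18 percentage points lower from compound 1 to compound 2 (beyond the scatter), runs in the opposite direction.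

Compound 4 `Nc1nc2c(c(=O)n(CC3CC3)c(=O)n2CC2CC2)n1Cc1cccc2ccccc12` has not yet been measured. Its difference from compound 3 is naphthalen-1-yl in place of 4-methoxyphenyl on a saturated chain carbon bound to an aromatic nitrogen. For the measured compounds named here, the steps that bear on this change are those that end in compound 3: a number 30 percentage points higher from compound 1 to compound 3 (beyond the scatter) and a number 48 percentage points higher from compound 2 to compound 3 (beyond the scatter), both of which put an aryl group on the saturated chain carbon bound to an aromatic nitrogen and both of which raise inhibition. Going by the values given here, no measured step swaps one aryl group for another, so the data give no direct guide to the size of the step from compound 3 to compound 4. Compound 4 is therefore expected to keep the aryl group's advantage, with an estimated step of no change at the digits printed from compound 3 to compound 4 (within the scatter), not clearly beyond the scatter in either direction. Compound 4 is estimated at 60%, within the range 35% to 85%.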

Compound 4, a percentage reported as inhibition, at one concentration (the size of the read-out at that concentration, not a potency): 0%
Compound 4: the middle estimate sits 60 percentage points above what was measured; the measured number lies below the stated range.
By their numbers in this assay, from the lowest: compound 4; then compound 2; then compound 1; then compound 3.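

In this assay, the result separates one aryl group from another at this place, on a saturated chain carbon bound to an aromatic nitrogen: a number 60 percentage points lower from compound 3 to compound 4 (beyond the scatter) for naphthalen-1-yl in place of 4-methoxyphenyl, so an aryl group there does not by itself raise inhibition. Naphthalen-1-yl also compares unfavourably with the two non-aryl cases, with a number 12 percentage points lower from compound 2 to compound 4 (beyond the scatter) against isopropyl and a number 30 percentage points lower from compound 1 to compound 4 (beyond the scatter) against hydrogen, which leaves compound 4 lowest of the four, with all three steps printed as beyond the scatter. Nothing available bears on what lies behind this drop.

Still open, on these data alone, is whether the low number goes with the second six-membered aromatic ring of naphthalen-1-yl or with the loss of the methoxy group of compound 3, and a plain phenyl or a naphthalen-2-yl at the same place would help separate the two. With a single aryl swap on the shared core, and each compound read at only one concentration, the trend across aryl groups and any difference in potency also remain undefined.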